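The compounds below may be only part of what the source reports. "The series", "measured", "known", "first", "only" and "open" are said of these compounds alone.

Compound 3 `COc1nc2ccc(Br)cc2cc1C(c1ccccc1)n1cc(CCO)nn1` carries a 2-hydroxyethyl group on the shared core. In an ADME assay on HeLa cells (Homo sapiens) for cytotoxicity, read by sulforhodamine B assay, with a stated time of 48 h, tested at 10 uM (a higher number here means more inhibition at the concentration tested (going by the name of the read-out), a lower number less inhibition), compound 3 gives 0.85%, the second highest of three numbers: compound 2 `COc1nc2ccc(Br)cc2cc1C(c1ccccc1)n1cc(CCCO)nn1` gives 11.3% and compound 1 `CCCCCc1cn(C(c2ccccc2)c2cc3cc(Br)ccc3nc2OC)nn1` gives -9.81%. Compound 4 `COc1nc2ccc(Br)cc2cc1C(c1ccccc1)n1cc(-c2ccccc2C(F)(F)F)nn1` differs from compound 3 in one place: 2-(trifluoromethyl)phenyl in place of 2-hydroxyethyl on an aromatic carbon. The measured steps were all modest, a number 10.7 percentage points higher from compound 1 to compound 3 (beyond the scatter), a number 10.5 percentage points lower from compound 2 to compound 3 (beyond the scatter) and a number 21.1 percentage points higher from compound 1 to compound 2 (beyond the scatter), yet each swapped one open chain for another, and none put an aromatic ring at this position, so none bears directly on the change. The expected step is therefore a number 4.2 percentage points higher from compound 3 to compound 4 (within the scatter), small and uncertain in direction. Compound 4 is estimated in this assay at 5%, with a range from -15% to 30%.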

Compound 4, a percentage reported as inhibition, at one concentration (the size of the read-out at that concentration, not a potency): -1.3%
Compound 4: middle estimate off by 6.3 percentage points, on the high side; the measured number falls inside the stated range.
By their numbers in this assay, from the lowest: compounds 1, 4 and 3 (each within the scatter of the next, the first and the last beyond it); then compound 2.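

Placing an aromatic ring at this position, on the five-membered ring, gives a number close to those of two open chains: the step for 2-(trifluoromethyl)phenyl against 2-hydroxyethyl is a number 2.2 percentage points lower from compound 3 to compound 4 (within the scatter), and against pentyl it is a number 8.5 percentage points higher from compound 1 to compound 4 (within the scatter). Only 3-hydroxypropyl stands apart in this assay, with a number 12.6 percentage points lower from compound 2 to compound 4 (beyond the scatter). Nothing available explains these numbers. Still open, on these data alone, is how plain phenyl, without the trifluoromethyl group, would read here. Also open, as far as these compounds go, is whether an amine or carboxylic acid at the end of the chain would read differently from the hydroxy group.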